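Seven-substituted eight-oxoguanosine analogues: YAC-1 activation notes

The source may hold more compounds than are shown below. What is called first, only, known or untested is meant among the compounds shown, and "the series" means these compounds.

Measured compounds:
compound 1 `C=CCn1c(=O)n(C2C[C@H](O)C(CO)O2)c2nc(N)nc(O)c21` — 100 uM
compound 2 `C=CCn1c(=O)n(C2C=CC(CO)O2)c2nc(N)nc(O)c21` — 11 uM
compound 3 `Cn1c(=O)n(C2OC(CO)[C@@H](O)[C@H]2O)c2nc(N)nc(O)c21` — 56 uM

The read-out throughout is a functional assay on YAC-1 cells (Mus musculus) for activation; on this read-out higher numbers stand for an effect only at larger amounts of compound and lower numbers for an effect already at smaller amounts. Compound 3 stands second highest of the three numbers in this assay. Its nearest neighbour is compound 1, whose number is within the scatter of that of compound 3, so no order between the two can be stated. Compound 2 is furthest away, with a lower number that lies beyond the scatter. For the measured compounds named here, no two measured compounds differ in a single place, so no step between measured compounds is available.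

Compound 4 `Nc1nc(O)c2c(n1)n(C1OC(CO)[C@@H](O)[C@H]1O)c(=O)n2Cc1ccc([N+](=O)[O-])cc1` is not yet measured. It differs from compound 3 as follows: 4-nitrophenyl in place of hydrogen on a saturated chain carbon bound to an aromatic nitrogen. Going by the values given here, nothing among the measured compounds shows how a 4-nitrophenyl on this chain carbon behaves in this assay; the only comparison is between an allyl group and a methyl group, and this does not bear on the nitrophenyl addition.

The step from compound 3 to compound 4 is therefore expected to be small, a 1.4-fold lower number from compound 3 to compound 4 (0.15 log units; within the scatter), with no clear direction beyond the scatter. For compound 4 the estimate is 40 uM, ranging from 10 uM to 160 uM.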

Compound 4, concentration for half-maximal effect: 48 uM
Compound 4: middle estimate off by 1.2-fold (0.08 log units), on the low side; low and high end bracket the measured number.
By their numbers in this assay, from the lowest: compound 2; then compounds 4, 3 and 1 (each within the scatter of the next, the first and the last beyond it).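

In this assay, the series now has its first step at a saturated chain carbon bound to an aromatic nitrogen, and 4-nitrophenyl in place of hydrogen gives a 1.2-fold lower number from compound 3 to compound 4 (0.07 log units; within the scatter). Methyl and 4-nitrobenzyl therefore cannot be told apart here, even though the group that enters brings 9 heavy atoms and one six-membered aromatic ring, so this place tolerates a group of that size on the core of compound 3 without a readable difference. Nothing measured offers an explanation for this result.

Going by these compounds, whether the same holds for an unsubstituted benzyl, or for a benzyl carrying an amine or a carboxylic acid, remains open. Also open, on these data alone, is how 4-nitrobenzyl behaves on the cores of compound 1 and compound 2, and how a longer chain behaves at this place.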